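A Ring Replaces the Methyl Ester Side Group

The source may hold more compounds than are shown below. What is called first, only, known or untested is meant among the compounds shown, and "the series" means these compounds.

Compound 1 `CCCCCCCCCCCCCCCCCC(=O)OC[C@H](O)COP(=O)(O)OC[C@H](N)C(=O)O`: 1000 nM
Compound 2 `CCCCCCCCCCCCCCCCCC(=O)NC[C@@H](O)COP(=O)(O)OC[C@H](N)C(=O)O`: 5000 nM
Compound 3 `CCCCCCCCCCCCCCCCCC(=O)OC[C@@H](O)COP(=O)(O)OC[C@H](N)C(=O)OC`: > 10000 nM

All three compounds were tested in a functional assay on cells (Mast cell, Rattus norvegicus, strain Wistar) for activation, read by fluorescence, with a stated time of 15 min; on this read-out higher numbers stand for an effect only at larger amounts of compound and lower numbers for an effect already at smaller amounts. Compound 3 gives > 10000 nM, which is a limit of the assay and not a number. Compound 4 `CCCCCCCCCCCCCCCCCC(=O)OC[C@@H](O)COP(=O)(O)O[C@@H]1CN[C@@H](C(=O)O)C1` has not yet been measured. Its structure differs from that of compound 3 as follows: a group of 8 heavy atoms (5 carbon, 1 nitrogen, 2 oxygen; one five-membered non-aromatic ring with 1 hetero atom) in place of a group of 7 heavy atoms (4 carbon, 1 nitrogen, 2 oxygen; no ring), on an oxygen. In plain terms, a group containing a five-membered non-aromatic ring takes the place of the open-chain 2-amino-2-(methoxycarbonyl)ethyl group, on an oxygen whose other neighbours are phosphorus.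

The methoxycarbonyl is absent from compound 1, at 1000 nM, and from compound 2, at 5000 nM. Both give real numbers in this assay, so compound 4, which also lacks it, is expected to give a measurable response at a smaller amount than compound 3 requires. Among the measured compounds shown here, the ring has no measured precedent here, so only a moderate gain is expected. The expected change is an at least 2.5-fold lower number from compound 3 to compound 4 (0.39 log units; beyond the scatter). For compound 4 the estimated value is 4000 nM, with an expected range from 1000 nM to 10000 nM.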

Compound 4, half-maximal effective concentration: > 10000 nM
Compound 4: only a limit was reported (the forecaster's own chance of this, stated with the estimate: 35%); middle value at least 2.5-fold (0.39 log units) from the limit.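

Among the compounds shown here, compound 3 and compound 4 each give only a limit and not a number, so no step between them can be read: the limit of > 10000 nM in this assay, at which 2 of the 4 values shown sit.

The compounds shown leave open whether the five-membered ring group of compound 4 changes the response compared with the 2-amino-2-(methoxycarbonyl)ethyl group of compound 3.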